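Working notes on the aryl ether series, compound 4

This account rests on a few compounds, and the source may have more. Where it says the series, first, only, none or still open, it means among the compounds named here.

Measured so far, in a functional assay on HeLa cells (Homo sapiens) for antiproliferative activity, read by cell counting, with a stated time of 3 days; on this read-out higher numbers stand for weaker inhibition and lower numbers for stronger inhibition:
Compound 1, `COc1cc(Oc2ccccc2NC(C)=C2C(=O)CC(c3ccccc3)CC2=O)ccc1N`, gives 33 nM.
Compound 2, `CC(Nc1ccccc1Oc1cccc(F)c1)=C1C(=O)CC(c2ccccc2)CC1=O`, gives 550 nM.
Compound 3, `COc1cccc(Oc2ccccc2NC(C)=C2C(=O)CC(c3ccccc3)CC2=O)c1`, gives 93 nM.

Compound 3 sits second highest of the three numbers: the step of a 2.8-fold higher number from compound 1 to compound 3 (0.45 log units; beyond the scatter) and the step of a 5.9-fold lower number from compound 2 to compound 3 (0.77 log units; beyond the scatter) both lie beyond the scatter. Compound 4, `CC(Nc1ccccc1Oc1ccc(C(C)O)cc1)=C1C(=O)CC(c2ccccc2)CC1=O`, differs from compound 3 by 4-(1-hydroxyethyl)phenyl in place of 3-methoxyphenyl on an oxygen on an aromatic ring. Both measured steps bear on this, since each alters the same ring on the aryl ether: a 5.9-fold lower number from compound 2 to compound 3 (0.77 log units; beyond the scatter) and a 2.8-fold higher number from compound 1 to compound 3 (0.45 log units; beyond the scatter) show that changes here move the number beyond the scatter in either direction, with the ring carrying amino giving the lowest number. A modest lower number is expected for compound 4, because a 2.8-fold higher number from compound 1 to compound 3 (0.45 log units; beyond the scatter) went the same way when a ring bearing a hydrogen-bond donor was present, though the new ring is not that ring. The estimate for compound 4 is 60 nM, range 20 nM to 180 nM, meaning an expected step of a 1.6-fold lower number from compound 3 to compound 4 (0.19 log units; within the scatter).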

Compound 4, half-maximal inhibitory concentration: 75 nM
For compound 4 the middle estimate is 1.3-fold (0.10 log units) below the measured one, within the range that was stated.
By their numbers in this assay, from the lowest: compound 1; then compounds 4 and 3 (each within the scatter of the next); then compound 2.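

In this assay, the aryl ether ring accepts a para-free change of this size: 4-(1-hydroxyethyl)phenyl in place of 3-methoxyphenyl gives a 1.2-fold lower number from compound 3 to compound 4 (0.09 log units; within the scatter), so a ring carrying a hydrogen-bond donor and no methoxy holds the number where the methoxy ring had it. The same ring still separates clearly from the 3-fluorophenyl ring (a 7.3-fold lower number from compound 2 to compound 4 (0.87 log units; beyond the scatter)) and from the 4-amino-3-methoxyphenyl ring (a 2.3-fold higher number from compound 1 to compound 4 (0.36 log units; beyond the scatter)). Nothing available gives a reason for these differences.
Going by these compounds, what an acetyl or plain ethyl group would give in place of 1-hydroxyethyl remains open, as does a carboxylic acid on this ring.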